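Exocyclic aryl replaced by a propyl chain

The source may hold more compounds than are shown below. What is called first, only, known or untested is meant among the compounds shown, and "the series" means these compounds.

Compound 3 `CC(=O)OC[C@H]1O[C@@H](n2cc(CN3C(=O)/C(=C\c4cccs4)c4ccccc43)nn2)[C@H](OC(C)=O)[C@@H](OC(C)=O)[C@@H]1OC(C)=O` is known in a functional assay on HeLa cells (Homo sapiens) for cytotoxicity, read by sulforhodamine B assay, with a stated time of 48 h (on this read-out higher numbers stand for weaker inhibition and lower numbers for stronger inhibition), only as a limit, > 100000 nM. Compound 1 `CC(=O)OC[C@H]1O[C@@H](n2cc(CN3C(=O)/C(=C\c4ccc(C)cc4)c4ccccc43)nn2)[C@H](OC(C)=O)[C@@H](OC(C)=O)[C@@H]1OC(C)=O` likewise sits at a limit, > 100000 nM. Compound 2 `COc1ccc(/C=C2\C(=O)N(Cc3cn([C@@H]4O[C@H](COC(C)=O)[C@@H](OC(C)=O)[C@H](OC(C)=O)[C@H]4OC(C)=O)nn3)c3ccccc32)cc1OC` gives a number in this assay, 63400 nM. For the measured compounds named here, the step of an at least 1.5-fold higher number from compound 2 to compound 3 (0.19 log units; that floor lies within the scatter) is the only readable one touching compound 3; the step that the two limits leave unreadable from compound 1 to compound 3 cannot be sized, since both ends lie at the limit of > 100000 nM in this assay, at which 2 of the 3 values shown sit. Compound 4 `CCC/C=C1\C(=O)N(Cc2cn([C@@H]3O[C@H](COC(C)=O)[C@@H](OC(C)=O)[C@H](OC(C)=O)[C@H]3OC(C)=O)nn2)c2ccccc21` carries the change (propyl in place of thiophen-2-yl on a double-bonded chain carbon bound to a double-bonded ring carbon). Going by the values given here, no measured step involves an aliphatic chain at this position, so the evidence offers no direction. Compound 4 is therefore expected to stay near the limit, with an estimated step of a number no higher from compound 3 to compound 4 (the limit leaves the size open). The estimate for compound 4 in this assay is 100000 nM, spanning 50000 nM to 200000 nM.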

Compound 4, half-maximal inhibitory concentration: 46300 nM
For compound 4 the middle estimate is 2.2-fold (0.33 log units) above the measured one; measured number below the stated range.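

In this assay, propyl in place of thiophen-2-yl gives an at least 2.1-fold lower number from compound 3 to compound 4 (0.33 log units; beyond the scatter), and propyl in place of 4-methylphenyl gives an at least 2.1-fold lower number from compound 1 to compound 4 (0.33 log units; beyond the scatter). Against the remaining aryl group, 3,4-dimethoxyphenyl, propyl gives a 1.4-fold lower number from compound 2 to compound 4 (0.14 log units; within the scatter), so on this double-bonded chain carbon a group with no ring reads the same as that aryl group within the scatter.

Going by these compounds, whether a longer chain or a chain ending in an amine would shift the number stays open. The two steps from the limit compounds are only floors, and the step between those two compounds cannot be read: the limit of > 100000 nM in this assay, at which 2 of the 4 values shown sit.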